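This account rests on a few compounds, and the source may have more. Where it says the series, first, only, none or still open, it means among the compounds named here.

Working notes on a small series of purine thioethers tested in a functional assay on MCF7 cells (Homo sapiens) for antiproliferative activity, read by sulforhodamine B assay, with a stated time of 3 days; a lower number here means a stronger inhibitor, a higher number a weaker inhibitor.

Compound 1 `c1ccc(Sc2ncnc3[nH]cnc23)cc1` is the simplest member; in this assay compound 1 gives 31000 nM. Compound 2 `Fc1ccc(Sc2ncnc3[nH]cnc23)cc1` carries the same core and differs by fluoro in place of hydrogen on an aromatic carbon. In this assay compound 2 gives 31600 nM. The step of a 1.0-fold higher number from compound 1 to compound 2 (0.01 log units; within the scatter) shows that adding the fluoro here leaves the read-out essentially unchanged.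

Compound 3 `c1ccc(Sc2ncnc3c2ncn3C2COc3ccccc3CO2)cc1` belongs to a second core; how the two cores differ is not broken down here. In this assay compound 3 gives 7120 nM, the lowest number of the three measured compounds, and its gap to compound 1 and to compound 2 lies beyond the scatter in each case.

Compound 4 `Fc1ccc(Sc2ncnc3c2ncn3C2COc3ccccc3CO2)cc1` is not yet measured. It stands to compound 3 as compound 2 stands to compound 1: the change is fluoro in place of hydrogen on an aromatic carbon, and the place around the substituted carbon reads the same as for the earlier pair, so it is the same change on the second core. Among the compounds with values here, the only precedent for this change is the step from compound 1 to compound 2, which stayed within the scatter. On that basis the step expected in this assay is a 1.0-fold higher number from compound 3 to compound 4 (0.00 log units; within the scatter), essentially flat, because a 1.0-fold higher number from compound 1 to compound 2 (0.01 log units; within the scatter) was flat. Compound 4 is therefore expected to give about 7200 nM in this assay, with the likely range running from 3500 nM to 15000 nM. The measurement will show whether the second core behaves like the first under this change.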

Compound 4, half-maximal inhibitory concentration: 11200 nM
Estimate against measurement, compound 4: 1.6-fold (0.19 log units) below; the measured number falls inside the stated range.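

In this assay, fluoro in place of hydrogen on the second core, the change from phenylsulfanyl to (4-fluorophenyl)sulfanyl, gives a 1.6-fold higher number from compound 3 to compound 4 (0.20 log units; within the scatter), so on this core too the step stays within the scatter. Set beside the step on the first core, the new step does not differ from it: the same change on two cores in this assay, a 1.0-fold higher number (0.01 log units; within the scatter) from compound 1 to compound 2 and a 1.6-fold higher number (0.20 log units; within the scatter) from compound 3 to compound 4, 1.5-fold (0.19 log units) apart, within the scatter of two such steps This shows that, for these two pairs, the change carries from one core to the other without a difference that can be told from the scatter, and that neither core shows a clear response to it in this read-out. It does not show that the change would stay flat on any further core or in another assay, and two pairs that both sit within the scatter cannot establish a general rule for the series or reveal a small effect hidden by that scatter.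

The compounds shown leave open whether any other group at the same place on the aromatic ring, such as chloro, methoxy, an amine or a carboxylic acid, would move the number beyond the scatter on either core. They also leave open whether such a group would then act alike on both cores, which is the question that a flat pair of steps cannot answer.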